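The compounds below may be only part of what the source reports. "The series", "measured", "known", "first", "only" and "open" are said of these compounds alone.

Measured compounds: compound 1 `Cc1ccc(/C=N/c2ccc(OCc3ccccc3)cc2)c(O)c1` with 24400 nM; compound 2 `O=[N+]([O-])c1ccc(O)c(/C=N/c2ccc(OCc3ccccc3)cc2)c1` with 60900 nM; compound 3 `COc1ccc(/C=N/c2ccc(OCc3ccccc3)cc2)c(O)c1` with 23600 nM.

All three share a core and were tested in an assay on isolated protein for inhibition of Amine oxidase [flavin-containing] B (Homo sapiens), read by fluorescence and Amplex Red, with stated times of 15 min and 20 min; a higher number here means a weaker inhibitor, a lower number a stronger inhibitor. Compound 2 gives the highest number of the three: compound 1 and compound 3 both sit well below it, beyond the scatter, while the step of a 1.0-fold lower number from compound 1 to compound 3 (0.01 log units; within the scatter) lies within the scatter, so compound 1 and compound 3 cannot be told apart.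

Compound 4 `Oc1ccc(Br)cc1/C=N/c1ccc(OCc2ccccc2)cc1` has not yet been measured in this assay. It differs from compound 2 in one place: bromo in place of nitro on an aromatic carbon. Within the data shown here, no measured step changes a group at this place on the ring; the only measured step, from compound 1 to compound 3, concerns a different substituent and is within the scatter, so it gives little guidance on how much a change here can move the number. What the values do show is that compound 2, carrying the nitro group, stands apart from compound 1 and compound 3 on the high side.

On that basis compound 4 is expected to land near the values of compound 1 and compound 3 rather than at the value of compound 2, which would mean an estimated step of a 2.2-fold lower number from compound 2 to compound 4 (0.34 log units; beyond the scatter). The estimate for compound 4 in this assay is therefore 28000 nM, with a range from 12000 nM to 65000 nM, the wide range reflecting the absence of any measured step at this place.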

Compound 4, half-maximal inhibitory concentration: 31700 nM
For compound 4 the middle estimate is 1.1-fold (0.05 log units) below the measured one, within the range that was stated.
By their numbers in this assay, from the lowest: compounds 3, 1, 4 and 2 (each within the scatter of the next, the first and the last beyond it).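

In this assay, among these compounds, the result gives the first measured step at this place on the ring, para to a hydroxy group: a 1.9-fold lower number from compound 2 to compound 4 (0.28 log units; within the scatter), so exchanging nitro for bromo here does not shift the number beyond the usual scatter. Compound 2 had stood apart from compound 1 and compound 3, but compound 4 does not fall clearly on either side, since it is also within the scatter of compound 2's lower neighbours, as a 1.3-fold higher number from compound 1 to compound 4 (0.11 log units; within the scatter) shows, although that step also changes the methyl group's place on the ring and so is not a clean reading of bromo alone. Nothing available explains why these two groups cannot be told apart at this place.

The compounds shown leave open whether any group at this place can move the number beyond the scatter, since only nitro and bromo have been seen here, and an amine, a carboxylic acid or a plain hydrogen could behave differently. They also leave open whether the hydroxy group itself is needed, as every compound shown carries it.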